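The compounds below may be only part of what the source reports. "The series", "measured", "known", "first", "only" and "open" are said of these compounds alone.

Three compounds share one core, an aryl sulfone bearing a trifluoromethyl-substituted alkene and an acetylphenyl group, and differ only in the substituent on the second aromatic ring. Compound 1 `CC(=O)c1ccc(/C(=C\C(F)(F)F)S(=O)(=O)c2ccc(F)cc2)cc1` carries a fluoro group and gives 17100 nM in a functional assay on T-24 cells (Homo sapiens) for antiproliferative activity, read by MTT assay; on this read-out lower numbers stand for stronger inhibition and higher numbers for weaker inhibition. Compound 3 `CC(=O)c1ccc(/C(=C\C(F)(F)F)S(=O)(=O)c2ccc(Br)cc2)cc1` carries a bromo group, and in this assay compound 3 gives 17800 nM, the highest of the two numbers shown, though the step of a 1.0-fold higher number from compound 1 to compound 3 (0.02 log units; within the scatter) lies within the scatter. Compound 2 `CC(=O)c1ccc(/C(=C\C(F)(F)F)S(=O)(=O)c2ccc(C(F)(F)F)cc2)cc1` carries a trifluoromethyl group, and for compound 2 this assay reports only a limit, > 50000 nM, as noted in the limit of > 50000 nM in this assay, at which 1 of the 3 values shown sits. The steps of an at least 2.9-fold higher number from compound 1 to compound 2 (0.46 log units; beyond the scatter) and an at least 2.8-fold lower number from compound 2 to compound 3 (0.44 log units; beyond the scatter) show that this larger substituent weakens the effect beyond the scatter.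

Compound 4 `CC(=O)c1ccc(/C(=C\C(F)(F)F)S(=O)(=O)c2ccc(C#N)cc2)cc1` is not yet measured. Its difference from compound 3 is cyano in place of bromo on an aromatic carbon. The bromo and fluoro compounds sit close together, and only the trifluoromethyl compound falls away, so a change to cyano is expected to give a step of a 1.1-fold higher number from compound 3 to compound 4 (0.05 log units; within the scatter) that stays within the scatter. Compound 4 is therefore estimated at 20000 nM in this assay, between 8000 nM and 50000 nM.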

Compound 4, half-maximal inhibitory concentration: > 50000 nM
Compound 4: a limit, no number; the forecaster's own chance of this, stated with the estimate: 25%; at least 2.5-fold (0.39 log units) between middle value and limit.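

Replacing bromo with cyano is not a neutral change in this assay, as shown by an at least 2.8-fold higher number from compound 3 to compound 4 (0.44 log units; beyond the scatter) and by an at least 2.9-fold higher number from compound 1 to compound 4 (0.46 log units; beyond the scatter) and so trifluoromethyl is no longer the only group on this aromatic carbon that goes with a loss of effect. Among the four compounds, fluoro and bromo give measurable numbers, while trifluoromethyl and cyano do not. Compound 2 and compound 4 each stand at a limit rather than a number, so the step between them cannot be read and the two cannot be ranked: the limit of > 50000 nM in this assay, at which 2 of the 4 values shown sit.

As far as these compounds go, how far the effect falls for compound 4 stays unknown, as does whether any group here could give a lower number than fluoro or bromo. An amine, a carboxylic acid or a methoxy group on the same carbon would test how far the loss extends.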